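Replacing a Chloro Group with an Aminopiperidine Ring

The source may report more compounds than this note shows. Statements on the series, on what has been measured and on what is new or still open speak of the compounds shown alone.

Compound 1 `CS(=O)(=O)c1cc(C(=O)N=C(N)N)c(Cl)cc1N1CCC(N)CC1`: 20 nM
Compound 2 `Cc1ccc(C(=O)N=C(N)N)cc1S(C)(=O)=O`: 210 nM
Compound 3 `CS(=O)(=O)c1cc(C(=O)N=C(N)N)ccc1Cl`: 380 nM

All three were tested in a functional assay for inhibition of sodium/hydrogen exchanger (Oryctolagus cuniculus); on this read-out higher numbers stand for weaker inhibition and lower numbers for stronger inhibition. Compound 3 gives the highest number of the three; its nearest neighbour is compound 2, and the step of a 1.8-fold higher number from compound 2 to compound 3 (0.26 log units; within the scatter) stays within the scatter, whereas compound 1 sits far lower. Compound 4 `CS(=O)(=O)c1cc(C(=O)N=C(N)N)ccc1N1CCC(N)CC1` arises from compound 3 by the change (4-aminopiperidin-1-yl in place of chloro on an aromatic carbon). Among the compounds with values here, no measured step covers exactly this change. The closest bearing comes from compound 1, which carries the same 4-aminopiperidin-1-yl group together with an additional chloro and gives 20 nM, whereas compound 3 gives 380 nM. A large drop in the number is therefore expected, a 9.5-fold lower number from compound 3 to compound 4 (0.98 log units; beyond the scatter). The estimate for compound 4 is 40 nM, with a range from 12 nM to 130 nM.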

Compound 4, half-maximal inhibitory concentration: 160 nM
Compound 4: middle estimate off by 4.0-fold (0.60 log units), on the low side; the measured number lies above the stated range.
By their numbers in this assay, from the lowest: compound 1; then compounds 4, 2 and 3 (each within the scatter of the next, the first and the last beyond it).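

In this assay, 4-aminopiperidin-1-yl in place of chloro brings only a modest gain, a 2.4-fold lower number from compound 3 to compound 4 (0.38 log units; beyond the scatter), and in place of methyl it gives a step within the scatter, a 1.3-fold lower number from compound 2 to compound 4 (0.12 log units; within the scatter). The low number of compound 1 therefore also depends on its additional chloro: hydrogen in place of that chloro gives an 8.0-fold higher number from compound 1 to compound 4 (0.90 log units; beyond the scatter). No measurement here explains these steps. On these data alone, it remains open whether a piperidin-1-yl group without its amine, or a simple dimethylamino group, on this aromatic carbon would give a similar number, and whether the additional chloro would lower the number with those groups too.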